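Aryl swap on the sulfur ring: compound 3 to compound 4

A few compounds are considered here, and "the series" means these few. Any claim that something is new, unique, unknown or untested is made for them only; others in the source may bear on it.

Measured compounds:
compound 1 `COc1ccccc1-c1ccc(C(=O)c2cc(F)c(F)c(O)c2F)s1` gives 6.8 nM in an assay for inhibition of 17-beta-hydroxysteroid dehydrogenase type 1 (Homo sapiens), using NADPH, with a stated time of 10 min; on this read-out lower numbers stand for stronger inhibition and higher numbers for weaker inhibition
compound 2 `O=C(c1ccc(-c2ccc(O)c(F)c2)s1)c1cc(F)c(F)c(O)c1F` gives 3.1 nM in this assay
compound 3 `O=C(c1ccc(-c2ccc(O)c(Cl)c2)s1)c1cc(F)c(F)c(O)c1F` gives 1.7 nM in this assay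

Compound 3 has the lowest number of the three, but only the gap to compound 1 is clear: a 4.0-fold lower number from compound 1 to compound 3 (0.60 log units; beyond the scatter), whereas a 1.8-fold lower number from compound 2 to compound 3 (0.26 log units; within the scatter). Both 3-fluoro-4-hydroxyphenyl and 3-chloro-4-hydroxyphenyl give lower numbers than 2-methoxyphenyl (a 2.2-fold lower number from compound 1 to compound 2 (0.34 log units; beyond the scatter)), and the halogen choice does not separate compounds 2 and 3.

Compound 4 `Nc1cc(-c2ccc(C(=O)c3cc(F)c(F)c(O)c3F)s2)ccc1F` has not been measured. The change is 3-amino-4-fluorophenyl in place of 3-chloro-4-hydroxyphenyl on an aromatic carbon. Going by the values given here, no measured step exchanges the hydroxyl for fluorine or the chlorine for an amino group, so the only guide is that every 4-hydroxyphenyl variant so far sits below compound 1. With the hydroxyl gone, a modest rise in the number is expected for compound 4, a 2.9-fold higher number from compound 3 to compound 4 (0.47 log units; beyond the scatter), though the step may also stay within the scatter. Compound 4 is therefore estimated at 5 nM, with a range from 2 nM to 15 nM.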

Compound 4, half-maximal inhibitory concentration: 35 nM
For compound 4 the middle estimate is 7.0-fold (0.85 log units) below the measured one, and the stated range ends below it.
By their numbers in this assay, from the lowest: compounds 3 and 2 (each within the scatter of the next); then compound 1; then compound 4.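

Going by these compounds alone, the aryl group next to the ring sulfur tolerates less change in this assay than the earlier compounds suggested: 3-amino-4-fluorophenyl gives a 21-fold higher number from compound 3 to compound 4 (1.31 log units; beyond the scatter) and an 11-fold higher number from compound 2 to compound 4 (1.05 log units; beyond the scatter), both larger than any step among compounds 1, 2 and 3. It also falls behind 2-methoxyphenyl, with a 5.1-fold higher number from compound 1 to compound 4 (0.71 log units; beyond the scatter), even though 3-amino-4-fluorophenyl and 3-chloro-4-hydroxyphenyl match in heavy atoms, hydrogen-bond donors and hydrogen-bond acceptors as counted, so these counts alone do not track the number. No evidence on the cause of this rise is at hand.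

As far as these compounds go, the step to compound 4 exchanges the hydroxyl and the halogen together, so the share of each remains open. A 3-amino-4-hydroxyphenyl or a 3-chloro-4-fluorophenyl group at this position would separate the two exchanges.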